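Hydroxy in Place of Fluoro: Estimating Compound 4

This account rests on a few compounds, and the source may have more. Where it says the series, first, only, none or still open, it means among the compounds named here.

Of the compounds shown here, three with a shared core have been tested in an in vitro assay on BTI-TN-5B1-4 cells for inhibition of Amine oxidase [flavin-containing] B (Homo sapiens), read by fluorescence; a lower number here means a stronger inhibitor, a higher number a weaker inhibitor. Compound 1 `NCCNC(=O)c1cc2ccccc2oc1=O` gives 7680 nM, compound 2 `O=C(Nc1ccccc1)c1cc2ccccc2oc1=O` gives 760 nM, and compound 3 `O=C(Nc1ccc(F)cc1)c1cc2ccccc2oc1=O` gives 67 nM, the lowest of the three. The step of an 11-fold lower number from compound 2 to compound 3 (1.05 log units; beyond the scatter) shows that one fluoro on the phenyl ring made a large difference. Compound 4 `O=C(Nc1ccc(O)cc1)c1cc2ccccc2oc1=O` differs from compound 3 by hydroxy in place of fluoro on an aromatic carbon. Among the measured compounds shown here, no measured step exchanges fluoro for hydroxy; the only guide is that compound 2, which carries no group at that carbon, sits far above compound 3, so the fluoro itself appears to matter. For compound 4 the expected step is a 7.5-fold higher number from compound 3 to compound 4 (0.87 log units; beyond the scatter), toward a weaker inhibitor. Compound 4 is estimated at 500 nM, with a range from 100 nM to 3000 nM.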

Compound 4, half-maximal inhibitory concentration: 800 nM
The estimate for compound 4 lay 1.6-fold (0.20 log units) below the measured number; the range from low to high includes it.
By their numbers in this assay, from the lowest: compound 3; then compounds 2 and 4 (each within the scatter of the next); then compound 1.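

Exchanging fluoro for hydroxy on this aromatic carbon, para to a large group, is a large change (a 12-fold higher number from compound 3 to compound 4 (1.08 log units; beyond the scatter)), although each group has a single heavy atom. Hydroxy in place of hydrogen stays within the scatter (a 1.1-fold higher number from compound 2 to compound 4 (0.02 log units; within the scatter)), so among these compounds only fluoro sets itself apart from the plain phenyl. The 4-hydroxyphenyl amide still differs clearly from the 2-aminoethyl amide (a 9.6-fold lower number from compound 1 to compound 4 (0.98 log units; beyond the scatter)). Nothing shown gives a reason for the gap between fluoro and hydroxy. On these data alone, whether chloro, methoxy or an amine on this carbon would fall nearer fluoro or hydroxy remains open.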